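A hydroxycarbamoyl group replacing the (methylcarbamoyl)methyl group

A few compounds are considered here, and "the series" means these few. Any claim that something is new, unique, unknown or untested is made for them only; others in the source may bear on it.

In a functional assay on HepG2 cells (Homo sapiens) for inhibition, read by MTT assay, with a stated time of 72 h (a higher number here means a weaker inhibitor, a lower number a stronger inhibitor), compound 1 `Nc1nc2cc(-c3nn(CCCCC(=O)NO)c4ncnc(N)c34)ccc2o1` gives 2100 nM, compound 2 `Nc1nc2cc(-c3nn(CCCCCC(=O)NO)c4ncnc(N)c34)ccc2o1` gives 1990 nM and compound 3 `CNC(=O)CCCCCCCn1nc(-c2ccc3oc(N)nc3c2)c2c(N)ncnc21` gives 3640 nM, so compound 3 cannot be told apart from the other two. Compound 4 `Nc1nc2cc(-c3nn(CCCCCCC(=O)NO)c4ncnc(N)c34)ccc2o1` is related to compound 3 by one change: hydroxycarbamoyl in place of (methylcarbamoyl)methyl on a saturated chain carbon, six bonds along the chain from an aromatic nitrogen. Going by the values given here, three measured steps bear on it. Two also separate a hydroxycarbamoyl-ended chain from a methylcarbamoyl-bearing one, and run in the opposite sense: a 1.7-fold higher number from compound 1 to compound 3 (0.24 log units; within the scatter) and a 1.8-fold higher number from compound 2 to compound 3 (0.26 log units; within the scatter). The third tracks chain length among the hydroxycarbamoyl compounds: a 1.1-fold lower number from compound 1 to compound 2 (0.02 log units; within the scatter). None leaves the scatter, so no step beyond it is expected. The expected change is a 1.9-fold lower number from compound 3 to compound 4 (0.28 log units; within the scatter). For compound 4 the estimated value is 1900 nM, with an expected range of 900 nM to 3600 nM.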

Compound 4, half-maximal inhibitory concentration: 1610 nM
For compound 4 the middle estimate is 1.2-fold (0.07 log units) above the measured one; the measured number falls inside the stated range.
By their numbers in this assay, from the lowest: compounds 4, 2, 1 and 3 (each within the scatter of the next, the first and the last beyond it).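

In this assay, going by these compounds alone, the change from (methylcarbamoyl)methyl to hydroxycarbamoyl at this place gives the first step in this set to go beyond the scatter (a 2.3-fold lower number from compound 3 to compound 4 (0.35 log units; beyond the scatter)). Among the hydroxycarbamoyl compounds, chain length still makes no clear difference, as both steps stay within the scatter (a 1.2-fold lower number from compound 2 to compound 4 (0.09 log units; within the scatter); a 1.3-fold lower number from compound 1 to compound 4 (0.12 log units; within the scatter)). No measurement shown here explains the effect of the change. From the compounds shown here alone, it remains open how a carboxylic acid or an amine would compare with hydroxycarbamoyl at the chain end. Going by these compounds, the effect of a longer chain also remains open.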